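A few compounds are considered here, and "the series" means these few. Any claim that something is new, unique, unknown or untested is made for them only; others in the source may bear on it.

Working notes on the series.

Three compounds have numbers in an assay on cells for inhibition of Voltage-dependent T-type calcium channel subunit alpha-1G (Homo sapiens), read by patch clamp; on this read-out lower numbers stand for stronger inhibition and higher numbers for weaker inhibition. Compound 1 `O=C(CC1c2ccccc2N=C(SCCCCCN2CCCC2)N1c1ccc(-c2ccccc2)cc1)NCc1ccc(F)cc1` gives 15000 nM in this assay, and compound 2 `CN(C)CCCCCSC1=Nc2ccccc2C(CC(=O)NCc2ccccc2)N1c1ccc(-c2ccccc2)cc1` gives 7770 nM. Compound 3 `O=C(CC1c2ccccc2N=C(SCCCCCN2CCCC2)N1c1ccc(-c2ccc(F)cc2)cc1)NCc1ccccc1` gives 2180 nM, the lowest of the three numbers; the gaps to compound 2 and to compound 1 both lie beyond the usual scatter, so compound 3 stands as the strongest inhibitor among the measured set. Going by the values given here, no two of these three compounds differ in only one place, so no single step between measured compounds can be read off.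

Compound 4 `O=C(CC1c2ccccc2N=C(SCCCCCN2CCCC2)N1c1ccc(-c2ccccc2)cc1)NCc1ccccc1` is the next compound, not yet measured in this assay. It differs from compound 3 by hydrogen in place of fluoro on an aromatic carbon, para to a large group. Among the compounds with values here, no measured pair shows the effect of this change, so the expectation rests on compound 3 alone. A small step is expected, toward a somewhat higher number, of the size a 1.5-fold higher number from compound 3 to compound 4 (0.17 log units; within the scatter), and likely within or close to the scatter. Compound 4 is estimated at 3200 nM, with a range from 1200 nM to 9000 nM.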

Compound 4, half-maximal inhibitory concentration: 660 nM
Estimate against measurement, compound 4: 4.8-fold (0.69 log units) above, outside the stated range (below it).
By their numbers in this assay, from the lowest: compound 4; then compound 3; then compounds 2 and 1 (each within the scatter of the next).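

In this assay, the change from 4-fluorophenyl to phenyl gives a 3.3-fold lower number from compound 3 to compound 4 (0.52 log units; beyond the scatter) and so fluoro on this aromatic carbon, para to a large group, goes with weaker inhibition, not stronger. Going by these compounds alone, compound 1 carries its fluoro on a different aromatic carbon, and hydrogen in its place gives a 23-fold lower number from compound 1 to compound 4 (1.36 log units; beyond the scatter) while pyrrolidin-1-yl in place of dimethylamino gives a 12-fold lower number from compound 2 to compound 4 (1.07 log units; beyond the scatter) as the one change on the chain, which leaves compound 4 as the strongest inhibitor of the four. No measurement shown here accounts for the size of these steps.

As far as these compounds go, whether the same trend holds for chloro or methoxy on these aromatic carbons remains open. Also open, from the compounds shown here alone, is how piperidin-1-yl in place of pyrrolidin-1-yl, or a longer chain to the sulfur, would read in this assay against compound 4.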